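Trimming a Methoxy Group on Compound 1

A few compounds are considered here, and "the series" means these few. Any claim that something is new, unique, unknown or untested is made for them only; others in the source may bear on it.

Compound 1, `COc1ccc(OC)c(C2=C(c3cc(OC)c(OC)c(OC)c3)C(=O)CC2O[SiH2]C(C)(C)C)c1`: 100 ug/mL
Compound 2, `COc1ccc(C2=C(c3cc(OC)c(OC)c(OC)c3)C(=O)CC2OC(C)=O)cc1NC=O`: > 100 ug/mL
Compound 3, `COc1ccc(OC)c(C2=C(c3cc(OC)c(OC)c(OC)c3)C(=O)CC2O)c1`: > 100 ug/mL

Within the data shown here, in an ADME assay on DU-145 cells (Homo sapiens) for cytotoxicity, read by MTT assay, with a stated time of 72 h (a higher number here means a weaker inhibitor, a lower number a stronger inhibitor), compound 1 gives 100 ug/mL, the only plain number among the three measured compounds. Compound 2 returns a limit of > 100 ug/mL. Compound 3 likewise returns a limit of > 100 ug/mL. Among the measured compounds shown here, the single measured one-site step, a number no lower from compound 1 to compound 3 (the limit leaves the size open), concerns the oxygen on the saturated carbon, and its size is hidden by the limit of > 100 ug/mL in this assay, at which 2 of the 3 values shown sit.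

Compound 4, `COc1ccc(C2=C(c3cc(OC)c(OC)c(OC)c3)C(=O)CC2O[SiH2]C(C)(C)C)cc1`, is not yet measured. It differs from compound 1 at another place: 4-methoxyphenyl in place of 2,5-dimethoxyphenyl on a double-bonded ring carbon. For the measured compounds named here, no measured step touches this aromatic ring, so none bears on the change, and the silyl ether that distinguishes compound 1 from compound 3 is kept in compound 4. With nothing to point either way, the expectation is a step no larger than the scatter, no change at the digits printed from compound 1 to compound 4 (within the scatter), with a real chance that the assay again reports only a limit. Compound 4 is therefore estimated at 100 ug/mL, in the range 50 ug/mL to 200 ug/mL.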

Compound 4, half-maximal inhibitory concentration: > 100 ug/mL
Compound 4: no number, only a limit (the forecaster's own chance of this, stated with the estimate: 50%); the middle value sits exactly at the limit.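

Compound 4 gives > 100 ug/mL in this assay as a limit of the assay and not a number. Among these compounds, this is the first measured change on the aromatic ring that carries the 2,5-dimethoxyphenyl group in compound 1, and it reads as a number no lower from compound 1 to compound 4 (the limit leaves the size open) so that, like the step at the oxygen, it cannot be read in size. Trimming to 4-methoxyphenyl yields no plain number, and the size of the change stays hidden because the values gather at the limit: the limit of > 100 ug/mL in this assay, at which 3 of the 4 values shown sit.

Compound 1 remains the only compound with a plain number, so the compounds shown leave open whether either methoxy group of the 2,5-dimethoxyphenyl ring matters at all. Also open, from the compounds shown here alone, is whether an amine or a fluorine on this ring in place of methoxy would give a plain number in this assay at all.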